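Cyclopropyloxy for methyl on the benzylamine ring

This account rests on a few compounds, and the source may have more. Where it says the series, first, only, none or still open, it means among the compounds named here.

Of the compounds shown here, three sharing one core have been measured in a functional assay on cells for positive allosteric modulation of G-protein coupled receptor 68 (Homo sapiens), read by a luciferase reporter and cAMP accumulation, with a stated time of 30 min, at pH 6.8 and pH 8.3, in the presence of a further agent that is not named here; on this read-out lower numbers stand for lower potency and higher numbers for higher potency (the scale is a negative logarithm). Compound 1 `Nc1nc(NCc2ccccc2)nc(-c2ccccc2CO)n1` gives 4.35. Compound 2 `Cc1ccc(CNc2nc(N)nc(-c3ccccc3CO)n2)cc1` gives 4.38, the highest of the three numbers, though its gap to compound 1, a number 0.03 log units higher from compound 1 to compound 2 (within the scatter), is within the scatter. Compound 3 `COc1ccccc1CNc1nc(N)nc(-c2ccccc2CO)n1` gives 3.99, which lies beyond the scatter below both: a number 0.36 log units lower from compound 1 to compound 3 (beyond the scatter) and a number 0.39 log units lower from compound 2 to compound 3 (beyond the scatter).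

Compound 4 `Nc1nc(NCc2ccc(OC3CC3)cc2)nc(-c2ccccc2CO)n1` differs from compound 2 by cyclopropyloxy in place of methyl on an aromatic carbon. Within the data shown here, the step that bears on it most closely is the one from compound 1 to compound 2, where adding methyl changed little; the two steps that introduce an oxygen-linked group, from compound 1 to compound 3 and from compound 2 to compound 3, were modest decreases, but at a different place on the ring. A small decrease, or no change beyond the scatter, is therefore expected in this assay. Compound 4 is estimated at 4.2, between 3.8 and 4.6. The step this estimate means, a number 0.18 log units lower from compound 2 to compound 4 (within the scatter), is expected to be small.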

Compound 4, negative logarithm of the antagonist equilibrium constant: 5.07
Compound 4: the middle estimate sits 0.87 log units below what was measured; the measured number lies above the stated range.
By their numbers in this assay, from the lowest: compound 3; then compounds 1 and 2 (each within the scatter of the next); then compound 4.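

In this assay, the aromatic carbon para to a large group proves responsive to the group placed on it: cyclopropyloxy gives a number 0.69 log units higher from compound 2 to compound 4 (beyond the scatter), and against the unsubstituted ring it gives a number 0.72 log units higher from compound 1 to compound 4 (beyond the scatter). Methyl at this carbon had left the number within the scatter, so compound 4 is the first to show that a change here can raise the number beyond it, while compound 3, with methoxy at a different place on the ring, goes the other way. Nothing available explains this gain.

The compounds shown do not separate the contributions of the oxygen and the three-membered ring. Ethoxy, isopropoxy or cyclopropyl on this same carbon would bear on that, and a longer chain such as butoxy or an amine would test how far the trend extends.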